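The source may report more compounds than this note shows. Statements on the series, on what has been measured and on what is new or still open speak of the compounds shown alone.

Measured compounds in an in vivo ADME assay on the whole organism for pharmacokinetics, with Rattus norvegicus as the target, at a dose of 10 mg/kg by the oral route; a lower number here means less compound in the circulation, a higher number more compound in the circulation at the dose given:
Compound 1, `CC1(COc2c(N3CCN(S(=O)(=O)Cc4ccc(N)c(C(F)(F)F)c4)CC3)cnn(-c3cccc(Cl)c3)c2=O)CC1`, gives 719 nM.
Compound 2, `CCc1cc(CS(=O)(=O)N2CCN(c3cnn(-c4cccc(Cl)c4)c(=O)c3OCC3(C)CC3)CC2)ccc1N`, gives 4020 nM.

Within the data shown here, compound 2 stands at the higher of these two numbers, and the one step measured so far, a 5.6-fold higher number from compound 1 to compound 2 (0.75 log units; beyond the scatter), separates it from compound 1. Compound 3, `CC(C)c1cc(CS(=O)(=O)N2CCN(c3cnn(-c4cccc(Cl)c4)c(=O)c3OCC3(C)CC3)CC2)ccc1N`, has not yet been measured. It differs from compound 2 by methyl in place of hydrogen on a saturated chain carbon bound to an aromatic carbon and a saturated chain carbon. The step of a 5.6-fold higher number from compound 1 to compound 2 (0.75 log units; beyond the scatter) concerns a different exchange of groups, so it gives only a loose guide to how adding a single methyl on a saturated chain carbon might play out. With nothing measured that matches this change, the number for compound 3 is expected to stay close to that of compound 2, giving a 1.1-fold lower number from compound 2 to compound 3 (0.06 log units; within the scatter), within the scatter. Compound 3 is therefore estimated at 3500 nM in this assay, with a likely range from 1200 nM to 10000 nM.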

Compound 3, maximal plasma concentration: 1190 nM
The estimate for compound 3 lay 2.9-fold (0.47 log units) above the measured number; the measured number lies below the stated range.
By their numbers in this assay, from the lowest: compounds 1 and 3 (each within the scatter of the next); then compound 2.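

In this assay, changing ethyl to isopropyl by adding one methyl on a saturated chain carbon bound to an aromatic carbon and a saturated chain carbon gives a 3.4-fold lower number from compound 2 to compound 3 (0.53 log units; beyond the scatter) and shows that this site responds to a single added carbon. Isopropyl in place of trifluoromethyl gives a 1.7-fold higher number from compound 1 to compound 3 (0.22 log units; within the scatter) and so cannot be told apart from trifluoromethyl here, while the ethyl compound, compound 2, stands apart from both by steps beyond the scatter. Nothing measured here explains why these changes do or do not shift the number.

Going by these compounds, it remains open how methyl or a straight propyl chain on that aromatic carbon would compare. On these data alone, it also remains open whether ethyl is unusual among such groups or whether other small chains would give similar numbers.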